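From phenethyl to 1,2-oxazol-5-yl on a carbonyl carbon

The source may hold more compounds than are shown below. What is called first, only, known or untested is meant among the compounds shown, and "the series" means these compounds.

Measured values in a toxicity assay on THP-1 cells (Homo sapiens) for inhibition (a lower number here means that less compound is tolerated, a higher number that more compound is tolerated), follow
compound 1 `COc1ccc(-c2cnc(NC(=O)c3cnc[nH]3)n2C)cc1` gives > 100000 nM
compound 2 `COc1ccc(-c2cnc(NC(=O)c3cccnc3)n2C)cc1` gives > 100000 nM
compound 3 `COc1ccc(-c2cnc(NC(=O)CCc3ccccc3)n2C)cc1` gives > 100000 nM

Each of these values is a limit of the assay and not a number. Compound 3 therefore has no exact place on the scale, only its limit (> 100000 nM). Compound 4 (`COc1ccc(-c2cnc(NC(=O)c3ccno3)n2C)cc1`) carries 1,2-oxazol-5-yl in place of phenethyl on a carbonyl carbon.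

Three measured changes on that carbonyl carbon bear on this one: (a step that the two limits leave unreadable from compound 1 to compound 2), (a step that the two limits leave unreadable from compound 1 to compound 3) and (a step that the two limits leave unreadable from compound 2 to compound 3). None of them has a size that can be read. Going by the values given here, compound 4 is expected to stay in the same region because of the limit of > 100000 nM in this assay, at which 3 of the 3 values shown sit, and no measured step points away from it. No step beyond the scatter and no direction is expected in this assay for this change, and the estimated step is (a number no higher from compound 3 to compound 4 (the limit leaves the size open)). Compound 4 is estimated at 100000 nM within an expected range from 40000 nM to 200000 nM in this assay as well.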

Compound 4, half-maximal cytotoxic concentration: > 100000 nM
Compound 4: no number, only a limit; the forecaster's own chance of this, stated with the estimate: 85%; the middle value sits exactly at the limit.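

No step between compound 4 and compound 1, compound 2 or compound 3 can be read in this assay, where all the values are limits of the assay and not numbers: the limit of > 100000 nM in this assay, at which 4 of the 4 values shown sit.

The compounds shown leave open where any of them lies on the scale, and whether the groups on the carbonyl carbon differ at all in half-maximal cytotoxic concentration.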